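Enantiomer pair at the saturated ring carbon

The source may report more compounds than this note shows. Statements on the series, on what has been measured and on what is new or still open speak of the compounds shown alone.

Compound 2 `CCN1CCC[C@](COCc2cc(C(F)(F)F)cc(C(F)(F)F)c2)(c2ccccc2)CC1` stands at 32 nM in an in vitro assay on U-373MG ATCC cells for displacement of a labelled ligand from Substance-P receptor (Homo sapiens), read by scintillation counting, with a stated time of 1 h (on this read-out higher numbers stand for weaker inhibition and lower numbers for stronger inhibition), the higher of the two numbers held so far. Compound 1 `FC(F)(F)c1cc(COCC2(c3ccccc3)CCCNC2)cc(C(F)(F)F)c1`, drawn without configuration at the ring carbon, gives 19 nM in this assay; the gap between compound 1 and compound 2 lies within the scatter, so no order between them is claimed.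

Compound 3 `CCN1CCC[C@@](COCc2cc(C(F)(F)F)cc(C(F)(F)F)c2)(c2ccccc2)CC1` is the partner of compound 2: the two compounds have the same atoms and bonds and differ only in configuration as drawn: 1 of 1 stereo elements differ; a stereocentre at a saturated ring carbon is drawn R in compound 2 and S in compound 3. Going by the values given here, no measured pair shows what such a change does here. Enantiomers of this kind may part widely or not at all; the number for compound 1, which carries no drawn configuration, is read as consistent with compound 3 standing at a lower number than compound 2, and the step is expected to run downward, beyond the scatter but not by a large margin.

Compound 3 is estimated at 12 nM in this assay, with a range from 3 nM to 60 nM, an expected step of a 2.7-fold lower number from compound 2 to compound 3 (0.43 log units; beyond the scatter).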

Compound 3, half-maximal inhibitory concentration: 11 nM
The estimate for compound 3 lay 1.1-fold (0.04 log units) above the measured number; the measured number falls inside the stated range.
By their numbers in this assay, from the lowest: compounds 3, 1 and 2 (each within the scatter of the next, the first and the last beyond it).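

In this assay the drawn configuration at this saturated ring carbon has a measurable effect: going from R to S gives a 2.9-fold lower number from compound 2 to compound 3 (0.46 log units; beyond the scatter). The earlier compounds shown here offered no measured pair for this change, and the step now sets a first size for it at this position, modest but clear of the scatter. The step can be assigned to this stereocentre alone because of one fact: the fact that compounds 2 and 3 differ only in the configuration as drawn.

The compounds shown leave open whether S stays the favoured configuration when the ethyl group is replaced by a propyl chain or an acetyl group, or when the phenyl group is replaced by a pyridyl group. They also leave open whether a step of this size would recur in another read-out, since this pair gives one number per configuration in a single assay.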